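A few compounds are considered here, and "the series" means these few. Any claim that something is new, unique, unknown or untested is made for them only; others in the source may bear on it.

Measured so far in a physicochemical assay for solubility, using the shake flask method, in phosphate buffer, measured as kinetic solubility, with a stated time of 20 h, at pH 6.5 (a lower number here means a less soluble compound, a higher number a more soluble compound), each value being a limit and not a number:

Compound 1 `FC(F)(F)c1cccc(-c2nc3cnc(Nc4ccccn4)cc3[nH]2)c1`: < 5000 nM
Compound 2 `FC(F)(F)c1cccc(-c2nc3cnc(Nc4ncccn4)cc3[nH]2)c1`: < 5000 nM
Compound 3 `FC(F)(F)c1cccc(-c2nc3cnc(Nc4cnccn4)cc3[nH]2)c1`: < 5000 nM

Compound 3 has no exact number and sits with the other two at the limit of < 5000 nM in this assay, at which 3 of the 3 values shown sit. Compound 4 `Fc1ccc(Nc2cc3[nH]c(-c4cccc(C(F)(F)F)c4)nc3cn2)nc1` carries 5-fluoropyridin-2-yl in place of pyrazin-2-yl on a nitrogen on an aromatic ring.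

The closest guides are the earlier swaps at that same place. These are a step that the two limits leave unreadable from compound 1 to compound 2, a step that the two limits leave unreadable from compound 1 to compound 3 and a step that the two limits leave unreadable from compound 2 to compound 3. None of them has a size that can be read, so none points in a direction.

The only anchor in this assay is compound 3 at < 5000 nM, which is a limit, so no step beyond the usual scatter is expected. The expected change is a step that the limit leaves unreadable from compound 3 to compound 4, with no firm direction. Compound 4 is estimated at 2500 nM, within an expected range from 800 nM to 5000 nM. The assay may well report only a limit again.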

Compound 4, solubility: < 5000 nM
Compound 4 ended at the assay's limit (the forecaster's own chance of this, stated with the estimate: 85%); the middle value lies beyond the limit too.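

In this assay compound 4 gives < 5000 nM, which is a limit and not a number. No step from compound 1, compound 2 or compound 3 to compound 4 can be read: the limit of < 5000 nM in this assay, at which 4 of the 4 values shown sit.

From the compounds shown here alone, the actual solubility of all four compounds stays open, as does whether swapping the ring on the nitrogen changes it at all.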